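A few compounds are considered here, and "the series" means these few. Any claim that something is new, unique, unknown or untested is made for them only; others in the source may bear on it.

In a functional assay on HCT-116 cells (Homo sapiens) for antiproliferative activity, read by MTT assay, with a stated time of 96 h (a lower number here means a stronger inhibitor, a higher number a weaker inhibitor), compound 1 (`COc1c(O)cc2cc1C[C@H](C)C[C@H](OC)[C@H](O)[C@@H](C)/C=C(\C)C[C@H](OC(N)=O)[C@@H](OC)CC/C=C(\C)C(=O)N2`) gives 1790 nM and compound 2 (`COc1ccc([C@H]2c3cccc(c3O)NC(=O)/C(C)=C/C=C\[C@H](OC)[C@@H](OC(N)=O)/C(C)=C/[C@H](C)[C@@H](O)[C@@H](OC)C[C@@H]2C)cc1`) gives 440 nM as the lower of the two numbers, a gap beyond the scatter. Compound 3 (`COc1ccc([C@H]2c3cccc(c3O)NC(=O)/C(C)=C/C=C\[C@H](OC)[C@@H](OC(N)=O)/C(C)=C/[C@H](C)[C@@H](OC)[C@@H](OC)C[C@@H]2C)cc1`) differs from compound 2 by having methyl in place of hydrogen on an oxygen on a saturated carbon, which turns hydroxy to methoxy (methyl in place of hydrogen on an oxygen on a saturated carbon). Going by the values given here, no measured pair shows this change, so the expectation is loose. In this assay a weaker inhibitor is expected, with an estimated 3.0-fold higher number from compound 2 to compound 3 (0.47 log units; beyond the scatter) as the step. The estimated value for compound 3 is 1300 nM (expected range 350 nM to 5000 nM).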

Compound 3, half-maximal inhibitory concentration: 6340 nM
Compound 3: the middle estimate sits 4.9-fold (0.69 log units) below what was measured; measured number above the stated range.
By their numbers in this assay, from the lowest: compound 2; then compound 1; then compound 3.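

In this assay, turning hydroxy to methoxy on this saturated carbon gives a 14-fold higher number from compound 2 to compound 3 (1.16 log units; beyond the scatter), the first change in one place among these compounds and a large step towards weaker inhibition. At this position, then, a single added methyl on the oxygen is enough to move the number well beyond the scatter. No measurement at hand accounts for this step. The compounds shown leave open how an amine in place of the hydroxy, or an ethyl on the same oxygen, would read in this assay.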